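Hydrogen in Place of Methoxy on Compound 3

The source may report more compounds than this note shows. Statements on the series, on what has been measured and on what is new or still open speak of the compounds shown alone.

compound 1 `CNC(=O)c1cc(S(=O)(=O)N2CCS[C@H]2C(=O)O[C@@H](Cc2c(Cl)c[n+]([O-])cc2Cl)c2ccc(OC(F)F)c(OCC3CC3)c2)cn1C` gives 12.6 nm/s
compound 2 `COc1ccc(S(=O)(=O)N2CCC[C@H]2C(=O)O[C@@H](Cc2c(Cl)c[n+]([O-])cc2Cl)c2ccc(OC(F)F)c(OCC3CC3)c2)cc1C(=O)N(C)C` gives 5 nm/s
compound 3 `COc1ccc(S(=O)(=O)N2CCCC[C@H]2C(=O)O[C@@H](Cc2c(Cl)c[n+]([O-])cc2Cl)c2ccc(OC(F)F)c(OCC3CC3)c2)cc1C(=O)N(C)C` gives 132 nm/s

In an ADME assay on Caco-2 cells (Homo sapiens) for permeability, read by LC-MS, in the apical to basolateral direction, with a stated time of 2 h, tested at 10 uM (a higher number here means that the compound crosses the layer faster, a lower number that the compound crosses the layer more slowly), compound 3 stands highest at 132 nm/s and lies beyond the scatter above both compound 1 and compound 2. Compound 4 `CN(C)C(=O)c1cccc(S(=O)(=O)N2CCCC[C@H]2C(=O)O[C@@H](Cc2c(Cl)c[n+]([O-])cc2Cl)c2ccc(OC(F)F)c(OCC3CC3)c2)c1` carries hydrogen in place of methoxy on an aromatic carbon, counted as hydrogen in place of methoxy on an aromatic carbon and otherwise matches compound 3. Within the data shown here, no measured pair shows this change alone. A step within the scatter is expected in this assay with no firm direction. The estimated 1.2-fold lower number from compound 3 to compound 4 (0.08 log units; within the scatter) is small, though the range stays wide. Compound 2 also carries the methoxy and gives 5 nm/s in the same assay. For compound 4 the estimate is 110 nm/s with an expected range from 40 nm/s to 260 nm/s in all.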

Compound 4, apparent permeability: 217 nm/s
Beside the measured number, compound 4's estimate is 2.0-fold (0.30 log units) below it; the measured number falls inside the stated range.
By their numbers in this assay, from the lowest: compound 2; then compound 1; then compounds 3 and 4 (each within the scatter of the next).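

In this assay, among these compounds, the step of a 1.6-fold higher number from compound 3 to compound 4 (0.22 log units; within the scatter) gives the first direct reading at this position, ortho to a dimethylcarbamoyl group and para to a large group. Replacing methoxy with hydrogen there produces no change that this assay can separate from the scatter, so the two compounds cannot be ranked. No measurement shown gives a reason for this result.

The compounds shown leave open how a fluorine atom, a hydroxyl group or an amine would read at this position. They also leave open whether the same replacement would read alike with the five-membered ring of compound 2 in place of the ring in compound 3.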